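A Methoxy Swap Among Tolerated Compounds

The source may hold more compounds than are shown below. What is called first, only, known or untested is meant among the compounds shown, and "the series" means these compounds.

In an ADME assay on MT4 cells (Homo sapiens) for cytotoxicity, read by MTT assay, with a stated time of 96 h (a higher number here means that more compound is tolerated, a lower number that less compound is tolerated), compound 1 `CC(=O)c1ccc2c(c1)nc(-c1ccccc1)n2C1CCCCC1` gives 37000 nM, and compound 2 `CC(=O)c1ccc2c(c1)nc(-c1ccc(C(F)(F)F)cc1)n2C1CCCCC1` gives 41000 nM, so the two stand level within the scatter. Compound 3 `COc1ccc(-c2nc3cc(C(C)=O)ccc3n2C2CCCCC2)cc1` carries methoxy in place of trifluoromethyl on an aromatic carbon, (methoxy in place of trifluoromethyl on an aromatic carbon). For the measured compounds named here, one measured step bears on this change: a 1.1-fold higher number from compound 1 to compound 2 (0.04 log units; within the scatter), where trifluoromethyl replaced hydrogen at that place. Going by the values given here, no methoxy compound has been measured, so the evidence is thin, and no shift beyond the scatter is expected in this assay. The expected step is a 1.1-fold lower number from compound 2 to compound 3 (0.03 log units; within the scatter). For compound 3 the estimated value is 38000 nM, with an expected range of 18000 nM to 75000 nM.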

Compound 3, half-maximal cytotoxic concentration: 27000 nM
Compound 3: the middle estimate sits 1.4-fold (0.15 log units) above what was measured; the measured number falls inside the stated range.
By their numbers in this assay, from the lowest: compounds 3, 1 and 2 (each within the scatter of the next).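

In this assay the methoxy change gives a 1.5-fold lower number from compound 2 to compound 3 (0.18 log units; within the scatter) and a 1.4-fold lower number from compound 1 to compound 3 (0.14 log units; within the scatter). This place has now carried hydrogen, trifluoromethyl and methoxy with no step beyond the scatter, even though methoxy brings a hydrogen-bond acceptor that the other two lack. Nothing measured here offers a cause for these small differences. The compounds shown leave open whether an amine or a carboxylic acid at this place would also stay within the scatter, and whether a change elsewhere on the shared core would move the number.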